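Fluorobenzyl amide series: one fluorine to two

This account rests on a few compounds, and the source may have more. Where it says the series, first, only, none or still open, it means among the compounds named here.

Compound 1 `COc1ccc2c(=O)c(/C=C/C(=O)NCc3cccc(F)c3)coc2c1` is the anchor of the set. Among the compounds with values here, in a functional assay on HeLa cells (Homo sapiens) for inhibition, read by MTT assay, with a stated time of 48 h (a higher number here means a weaker inhibitor, a lower number a stronger inhibitor), compound 1 gives 17600 nM, the only numeric value so far, so it stands alone rather than against a measured comparison. Compound 2 `COc1ccc(NC(=O)/C=C/c2coc3cc(O)ccc3c2=O)cc1` is the other measured entry; in this assay compound 2 gives > 100000 nM, which is a limit of the assay and not a number, and it sits at the limit of > 100000 nM in this assay, at which 1 of the 2 values shown sits. Within the data shown here, no measured step therefore frames the change from compound 1 to compound 3 `COc1ccc2c(=O)c(/C=C/C(=O)NCc3ccc(F)cc3F)coc2c1`, which is 2,4-difluorophenyl in place of 3-fluorophenyl on a saturated chain carbon bound to an amide-type nitrogen. With nothing measured on either side of this change, the expected step from compound 1 to compound 3 is a 1.2-fold lower number from compound 1 to compound 3 (0.07 log units; within the scatter), small and within the usual scatter, with no firm direction. Compound 3 is accordingly estimated at 15000 nM in this assay, with a range from 5000 nM to 50000 nM.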

Compound 3, half-maximal inhibitory concentration: > 100000 nM
Compound 3: no number, only a limit (the forecaster's own chance of this, stated with the estimate: 10%); middle value at least 6.6-fold (0.82 log units) away from the limit.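

On a saturated chain carbon bound to an amide-type nitrogen, 2,4-difluorophenyl in place of 3-fluorophenyl gives an at least 5.6-fold higher number from compound 1 to compound 3 (0.75 log units; beyond the scatter) in this assay, so this position responds to a change as small as one added fluorine. Compound 3 gives > 100000 nM, which is a limit of the assay and not a number. The full size of the step therefore cannot be read, and compound 1 remains the only compound with a number: the limit of > 100000 nM in this assay, at which 2 of the 3 values shown sit.

As far as these compounds go, whether the loss follows from the fluorine pattern as a whole or from one particular fluorine remains open. From the compounds shown here alone, it is also open whether a plain phenyl, 3-chlorophenyl or a longer chain ending in phenyl in this place would give a number in this assay.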